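The source may hold more compounds than are shown below. What is called first, only, known or untested is meant among the compounds shown, and "the series" means these compounds.

Compound 1 `COc1cc(/C=C/C(=O)c2cccc(NC(=O)c3cccs3)c2)ccc1O`: 3.98 ug/mL
Compound 2 `COc1cc(/C=C/C(=O)c2cccc(NC(=O)c3cc(Cl)cc(Cl)c3)c2)ccc1O`: > 50 ug/mL

These two compounds were tested in a functional assay on Vero cells (Chlorocebus sabaeus) for inhibition; a higher number here means a weaker inhibitor, a lower number a stronger inhibitor. On these data alone, compound 2 gives > 50 ug/mL, which is a limit of the assay and not a number, so its exact place is unknown.

Compound 3 `COc1cc(/C=C/C(=O)c2cccc(NC(=O)c3ccc(Cl)cc3)c2)ccc1O` has not yet been measured. It carries 4-chlorophenyl in place of 3,5-dichlorophenyl on a carbonyl carbon.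

Within the data shown here, one measured step bears on this change, as it alters the same place: an at least 12-fold higher number from compound 1 to compound 2 (1.09 log units; beyond the scatter). That step is large and beyond the scatter, so a change here can matter greatly. Like the group it replaces, 4-chlorophenyl is a six-membered aromatic ring of carbon only, unlike the thiophen-2-yl of compound 1. A move only part of the way toward compound 1 therefore seems likely, and a result at the limit remains possible.

The expected change is an at least 2.5-fold lower number from compound 2 to compound 3 (0.39 log units; beyond the scatter), toward a lower number. For compound 3 the estimate is 20 ug/mL, with an expected range of 6 ug/mL to 50 ug/mL.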

Compound 3, half-maximal inhibitory concentration: 3.82 ug/mL
The estimate for compound 3 lay 5.2-fold (0.72 log units) above the measured number; the whole stated range lies above it.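

In this assay, thiophen-2-yl is not required on this carbonyl carbon: the step to 4-chlorophenyl gives a 1.0-fold lower number from compound 1 to compound 3 (0.02 log units; within the scatter), so a six-membered aromatic ring of carbon only can match the thiophene here. Swapping 3,5-dichlorophenyl for 4-chlorophenyl gives an at least 13-fold lower number from compound 2 to compound 3 (1.11 log units; beyond the scatter). The poor result of compound 2 does not go with a carbon-only ring as such. It goes instead with the difference between these two chlorinated rings. The value of compound 2 is a limit of the assay and not a number, so the full size of this step stays unknown: the limit of > 50 ug/mL in this assay, at which 1 of the 3 values shown sits.

The compounds shown cannot tell whether the number of chlorines or their placement separates compound 2 from compound 3. On these data alone, how a plain phenyl group, or a ring bearing an amine or a carboxylic acid, would behave at this carbonyl carbon also remains open.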